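This account rests on a few compounds, and the source may have more. Where it says the series, first, only, none or still open, it means among the compounds named here.

Working notes on the series in a functional assay on MGC-803 cells (Homo sapiens) for antiproliferative activity, read by MTT assay, with a stated time of 72 h; a lower number here means a stronger inhibitor, a higher number a weaker inhibitor. Compound 1 `O=C(COc1ccc(C(=O)/C=C/c2cccc(Cl)c2)cc1)N[C@H]1CCOC1=O` gives 29100 nM in this assay. Compound 3 `O=C1OCC[C@@H]1NC(=S)SCCOc1ccccc1[N+](=O)[O-]` gives 47000 nM, a value that sits within the scatter of that of compound 1, so the two numbers are not separated. For compound 2 `O=C1OCC[C@@H]1NC(=S)SCCOc1cccc2ccccc12` this assay reports only a limit, > 64000 nM, and no number; this is the limit of > 64000 nM in this assay, at which 1 of the 3 values shown sits. Compound 1 thus stands with compound 3 among the two numbered values. Compound 4 `CC(C)(C)c1ccc(/C=C/C(=O)c2ccc(OCC(=O)N[C@H]3CCOC3=O)cc2)cc1` has not yet been measured in this assay. It differs from compound 1 by 4-(tert-butyl)phenyl in place of 3-chlorophenyl on a double-bonded chain carbon bound to a double-bonded chain carbon. For the measured compounds named here, no measured step covers this change, so its size rests on expectation alone. Compound 4 is estimated at 20000 nM, with a range from 6000 nM to 60000 nM. The expected step of a 1.5-fold lower number from compound 1 to compound 4 (0.16 log units; within the scatter) is judged small, not clearly beyond the scatter of this assay.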

Compound 4, half-maximal inhibitory concentration: 17200 nM
Compound 4: middle estimate off by 1.2-fold (0.07 log units), on the high side; low and high end bracket the measured number.
By their numbers in this assay, from the lowest: compounds 4, 1 and 3 (each within the scatter of the next, the first and the last beyond it). At a limit, above all of these: compound 2.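

On a double-bonded chain carbon bound to a double-bonded chain carbon, 4-(tert-butyl)phenyl in place of 3-chlorophenyl gives a 1.7-fold lower number from compound 1 to compound 4 (0.23 log units; within the scatter) in this assay. This position therefore accepts an exchange of these two substituted phenyl groups without separating compound 1 from compound 4. Nothing shown gives a reason for this step. The compounds shown leave open whether any group at this position can move the number beyond the scatter. An amine or a carboxylic acid on the phenyl ring would test this.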